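This account rests on a few compounds, and the source may have more. Where it says the series, first, only, none or still open, it means among the compounds named here.

Measured so far in a toxicity assay on HaCaT cells (Homo sapiens) for cytotoxicity, tested at 250 uM; on this read-out lower numbers stand for a stronger effect and higher numbers for a weaker effect at the one concentration tested:
Compound 1 `O=S(=O)(Nc1nnc(SCc2ccccc2)s1)c1ccccc1` gives 68%.
Compound 2 `O=S(=O)(Nc1nnc(SCc2ccc(Cl)cc2)s1)c1ccccc1` gives 71%.
Compound 3 `COc1ccc(S(=O)(=O)Nc2nnc(SCc3ccccc3)s2)cc1` gives 57%.

Compound 4 `COc1ccc(S(=O)(=O)Nc2nnc(SCc3ccc(Cl)cc3)s2)cc1` has not yet been measured. It differs from compound 3 by chloro in place of hydrogen on an aromatic carbon. The same change, (chloro in place of hydrogen on an aromatic carbon), turns compound 1 into compound 2, where it gave a number 3 percentage points higher from compound 1 to compound 2 (within the scatter). The core of compound 3 differs from the core of compound 1 by methoxy in place of hydrogen on an aromatic carbon, a change that gave a number 11 percentage points lower from compound 1 to compound 3 (beyond the scatter), so compound 3 stands lowest of the three measured numbers. Going by the values given here, for compound 4 a step of similar small size is expected, a number 3 percentage points higher from compound 3 to compound 4 (within the scatter), because the one earlier instance of this change gave a number 3 percentage points higher from compound 1 to compound 2 (within the scatter), and that rests on a single pair only. Compound 4 is therefore estimated at 60%, with a likely range from 48% to 72%.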

Compound 4, a percentage reported as activity, at one concentration (the size of the read-out at that concentration, not a potency): 79%
Estimate against measurement, compound 4: 19 percentage points below; measured number above the stated range.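

In this assay, the change from benzyl to 4-chlorobenzyl gives a number 22 percentage points higher from compound 3 to compound 4 (beyond the scatter), and its size does not carry over from one core to the other: the same change on two cores in this assay, a number 3 percentage points higher (within the scatter) from compound 1 to compound 2 and a number 22 percentage points higher (beyond the scatter) from compound 3 to compound 4, 19 percentage points apart, beyond the scatter of two such steps. The added methoxy gives a number 8 percentage points higher from compound 2 to compound 4 (within the scatter), and its step also depends on the core: the same change on two cores in this assay, a number 11 percentage points lower (beyond the scatter) from compound 1 to compound 3 and a number 8 percentage points higher (within the scatter) from compound 2 to compound 4, 19 percentage points apart, beyond the scatter of two such steps. So in these four compounds the two changes do not simply add up, but the data do not show why, and two pairs for each change give no rule for other cores.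

Open, going by these compounds, is whether a bromo or a methyl in place of the chloro, or an amine or a carboxylic acid in place of the methoxy, would show the same dependence on the core.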